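A Methyl Swapped for Methylamino

This account rests on a few compounds, and the source may have more. Where it says the series, first, only, none or still open, it means among the compounds named here.

Compound 1 `Cc1c(C(=O)Nc2nnn[nH]2)oc2ccccc2c1=O`: 0.4 ug/mL
Compound 2 `O=C(Cl)c1coc2ccccc2c1=O`: "nd(insoluble)" (no result reported)

In a functional assay on cells (Mast cell, Rattus norvegicus) for inhibition, with a stated time of 15 min (a higher number here means that more compound is needed for the effect, a lower number that less compound is needed), compound 1 gives 0.4 ug/mL. Among the compounds with values here, this is the only number available, so it cannot be ranked against anything, and compound 2 is recorded only as "nd(insoluble)" (no result reported), with no result reported.

Compound 3 `CNc1c(C(=O)Nc2nnn[nH]2)oc2ccccc2c1=O` keeps the core of compound 1 and changes one group, with methylamino in place of methyl on an aromatic carbon. The new group sits two atoms from the ring oxygen.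

Within the data shown here, no measured pair of compounds shows what such a change does, so there is no evidence for a direction. In this assay the expected result is therefore no shift beyond the scatter, and the estimated step is a 1.3-fold higher number from compound 1 to compound 3 (0.10 log units; within the scatter). The uncertainty stays wide. For compound 3 the estimated value is 0.5 ug/mL, with an expected range from 0.1 ug/mL to 2.5 ug/mL.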

Compound 3, concentration for half-maximal effect: 0.4 ug/mL
Compound 3: the middle estimate sits 1.3-fold (0.10 log units) above what was measured; low and high end bracket the measured number.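

In this assay, putting methylamino in place of methyl on this aromatic carbon, two atoms from the ring oxygen, gives no change at the digits printed from compound 1 to compound 3 (within the scatter) in the read-out. This position therefore accepts a group bringing a nitrogen, a hydrogen-bond donor and a hydrogen-bond acceptor that methyl lacks, with no shift in the number beyond the usual scatter. No measurement shown here explains why the two groups read alike.

The compounds shown leave open how this position responds to groups further removed from these two, such as dimethylamino, a longer chain or a carboxylic acid. Going by these compounds, with a single measured pair, it also remains open whether the same swap would read alike on another core or in another test.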